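Aryl swap on the ring amine: compound 2 to compound 4

The source may hold more compounds than are shown below. What is called first, only, known or untested is meant among the compounds shown, and "the series" means these compounds.

Measured so far in an assay on HEK293 cells for inhibition of Voltage-dependent T-type calcium channel subunit alpha-1G (Homo sapiens), read by fluorescence, tested at 10 uM; on this read-out higher numbers stand for more inhibition at the one concentration tested (going by the name of the read-out) and lower numbers for less inhibition:
- compound 1, `CCCc1nc(-c2ccccc2)c(CNCCCN2CCN(c3ccccc3)CC2)o1`, 43.7%
- compound 2, `CCCc1nc(-c2ccccc2)c(CNCCN2CCN(c3ccc(Cl)cc3)CC2)o1`, 55.8%
- compound 3, `CCCc1nc(-c2ccccc2)c(CNCCCN2CCN(c3cccc(Cl)c3)CC2)o1`, 65.9%

Compound 2 stands second highest of the three numbers in this assay: compound 3 lies above it by a margin beyond the scatter, and compound 1 lies below it by a margin beyond the scatter, so compound 2 sits between the other two rather than at either end.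

The next compound, compound 4, `CCCc1nc(-c2ccccc2)c(CNCCN2CCN(c3ccccc3OC)CC2)o1`, differs from compound 2 as follows: 2-methoxyphenyl in place of 4-chlorophenyl on an amine nitrogen in a ring.

Among the measured compounds shown here, only one measured step concerns a change on the same aromatic ring, and it is of a different kind: a number 22.2 percentage points higher from compound 1 to compound 3 (beyond the scatter), which introduces a halogen where there was none and also concerns the longer chain. For the measured compounds named here, no measured step removes a chloro or introduces a methoxy, so there is no direct guide to the direction of the present change. Going by the values given here, the one related step argues that substitution on that ring can shift the number by a modest amount, in either direction in principle. The expectation is therefore a modest change at most, with no firm direction, as a number 5.8 percentage points lower from compound 2 to compound 4 (within the scatter). For compound 4 the estimate in this assay is 50%, within a range from 30% to 70%.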

Compound 4, a percentage reported as inhibition, at one concentration (the size of the read-out at that concentration, not a potency): 39.7%
For compound 4 the middle estimate is 10.3 percentage points above the measured one; the measured number falls inside the stated range.
By their numbers in this assay, from the lowest: compounds 4 and 1 (each within the scatter of the next); then compound 2; then compound 3.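

In this assay, among the compounds shown here, the aryl group on the ring amine proves able to move the number downward as well as upward: 2-methoxyphenyl in place of 4-chlorophenyl gives a number 16.1 percentage points lower from compound 2 to compound 4 (beyond the scatter), whereas the one earlier step at this ring, chloro in place of hydrogen, gave a number 22.2 percentage points higher from compound 1 to compound 3 (beyond the scatter) on a different chain. Both steps lie beyond the scatter, so substitution on this aryl group matters on both chains shown, and the direction depends on the change made. The new step changes the group and its place on the aromatic ring together, and it adds a hydrogen-bond acceptor by the count for the entering group, so the contribution of each remains unseparated, and no measurement at hand accounts for the lower number.

Still open, going by these compounds, is whether the group or its place on the ring governs the step, which a comparison of 2-chlorophenyl and 4-methoxyphenyl on the chain of compound 2 would address. Also open, on these data alone, is whether the same swap gives a step of similar direction and size on the longer chain of compound 3.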